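Working notes: from compound 1 to compound 4

The compounds below may be only part of what the source reports. "The series", "measured", "known", "first", "only" and "open" are said of these compounds alone.

- compound 1 `Cc1c(OCCCCOc2ccc(C(=O)O)cc2F)ccc(C(=O)CC2CCCC2)c1O` reads 97%
- compound 2 `Cc1c(OCCCCOc2ccc(C(=O)O)cc2F)ccc(C(=O)CC(C)C)c1O` reads 106%
- compound 3 `Cc1c(OCCCCOc2ccc(C(=O)CC(C)(C)C)c(O)c2C)cccc1C(=O)O` reads 89%

All three numbers come from an ADME assay on a cell-free system (plasma, Rattus norvegicus) for metabolic stability, read by LC-MS, with a stated time of 60 min, tested at 100 uM (on this read-out lower numbers stand for a less stable compound and higher numbers for a more stable compound), and nothing else has been measured so far. Compound 1 (97%) lies within the usual scatter of both compound 3 and compound 2, so it gives a firm reference point but no clear rank among the three.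

Compound 4 `Cc1c(OCCCCOc2ccc(C(=O)O)c(Cl)c2)ccc(C(=O)CC2CCCC2)c1O` is still unmeasured. It carries 4-carboxy-3-chlorophenyl in place of 4-carboxy-2-fluorophenyl on an oxygen on a saturated carbon, and otherwise matches compound 1 4-carboxy-3-chlorophenyl in place of 4-carboxy-2-fluorophenyl on an oxygen on a saturated carbon in the rest of the structure.

Going by the values given here, only one measured step bears on this change, and only indirectly. That step, a number 9 percentage points higher from compound 1 to compound 2 (within the scatter), is an exchange at a different place, on the saturated chain carbon bound to a carbonyl carbon. Compound 3 is not joined to compound 1 by a single-place step. Among the compounds with values here, no measured step touches the carboxy-bearing aryl group, so the data give no direct size for this exchange.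

In this assay no step beyond the scatter is expected (no change at the digits printed from compound 1 to compound 4 (within the scatter)). Compound 4 is estimated at 97% (expected range 85% to 108%).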

Compound 4, percent of the compound remaining: 97%
Estimate against measurement, compound 4: no gap at the digits printed; measured number inside the range.
By their numbers in this assay, from the lowest: compounds 3, 1, 4 and 2 (each within the scatter of the next, the first and the last beyond it).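

In this assay, going by these compounds alone, putting 4-carboxy-3-chlorophenyl in place of 4-carboxy-2-fluorophenyl on the oxygen on a saturated carbon gives no change at the digits printed from compound 1 to compound 4 (within the scatter), the first measured step at this position, as the only earlier step lay on the saturated chain carbon bound to a carbonyl carbon. With the rest of the structure held constant, this read-out does not tell the two aryl groups apart, so this exchange of one halogen-bearing carboxyphenyl group for the other is tolerated in this one pair. No measurement in hand offers an explanation for this result.

Within the data shown here, the single pair does not separate the loss of the fluorine from the entry of the chlorine, and it remains open whether a plain 4-carboxyphenyl group, or a primary amide in place of the carboxylic acid, would also stay within the scatter of compound 1. On these data alone, it is equally open whether the same aryl exchange would read alike on the isopropyl compound 2 or on a core with a different acyl chain.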